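Removing an Ethyl Group and Cytotoxicity in Mouse Cells

A few compounds are considered here, and "the series" means these few. Any claim that something is new, unique, unknown or untested is made for them only; others in the source may bear on it.

Compound 1 `CCCCc1cc2c(=O)c(C(=O)OC)c[nH]c2cc1OCCOc1ccccc1`, compound 2 `CCCCc1ccc2[nH]cc(C(=O)OC)c(=O)c2c1` and compound 3 `CCc1ccc2[nH]cc(C(=O)OC)c(=O)c2c1` were tested in an ADME assay on J774 cells (Mus musculus) for cytotoxicity; a higher number here means that more compound is needed for the effect, a lower number that less compound is needed. In this assay compound 1 gives only a limit, > 20000 nM. Compound 2 likewise gives a limit, > 20000 nM. Compound 3 also gives a limit, > 20000 nM. The change from compound 2 to compound 3 is hydrogen in place of ethyl on a saturated chain carbon, two bonds along the chain from an aromatic carbon, and its step, a step that the two limits leave unreadable from compound 2 to compound 3, cannot be read because of the limit of > 20000 nM in this assay, at which 3 of the 3 values shown sit. Compound 4 `CCc1cc2c(=O)c(C(=O)OC)c[nH]c2cc1OCCOc1ccccc1`, not yet measured, differs from compound 1 by the same change, (hydrogen in place of ethyl on a saturated chain carbon, two bonds along the chain from an aromatic carbon); the difference between the cores of compound 1 and compound 2 is not broken down here. Resting on (the limit of > 20000 nM in this assay, at which 3 of the 3 values shown sit), the expected step is a step that the limit leaves unreadable from compound 1 to compound 4. In this assay compound 4 is therefore expected to give 30000 nM, between 15000 nM and 100000 nM, most likely again as a limit.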

Compound 4, half-maximal effective concentration: > 20000 nM
Compound 4: no number, only a limit; the forecaster's own chance of this, stated with the estimate: 90%; the middle value does not contradict the limit.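

No step can be read from compound 1 to compound 4, because both give only a limit: the limit of > 20000 nM in this assay, at which 4 of the 4 values shown sit.

Still open, from the compounds shown here alone, is whether, in this assay, going from butyl to ethyl changes the concentration that harms the cells.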